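Aminopiperidine for sulfamoylpiperazine on two related cores

This account rests on a few compounds, and the source may have more. Where it says the series, first, only, none or still open, it means among the compounds named here.

Compound 1 `Cc1cc(/C=C/C#N)cc(C)c1Oc1nc(Nc2ccc(N3CCCC(N)C3)cc2)nc2ccsc12` and compound 2 `Cc1cc(/C=C/C#N)cc(C)c1Oc1nc(Nc2ccc(N3CCN(S(N)(=O)=O)CC3)cc2)nc2ccsc12` share one core; compound 3 `Cc1cc(/C=C/C#N)cc(C)c1Oc1nc(Nc2ccc(N3CCN(S(N)(=O)=O)CC3)cc2)nc2sccc12` and compound 4 `Cc1cc(/C=C/C#N)cc(C)c1Oc1nc(Nc2ccc(N3CCCC(N)C3)cc2)nc2sccc12` share another, and how the two cores differ is not broken down here. In an ADME assay on MT4 cells (Homo sapiens) for cytotoxicity, read by MTT assay, with a stated time of 5 days (a lower number here means that less compound is tolerated, a higher number that more compound is tolerated), compound 1 gives 3820 nM. For compound 2 the value in this assay is only a limit of the assay, > 222000 nM. For compound 3 the value in this assay is likewise only a limit, > 222000 nM. Going by these compounds, the change 3-aminopiperidin-1-yl in place of 4-sulfamoylpiperazin-1-yl on an aromatic carbon produced an at least 58-fold lower number from compound 2 to compound 1 (1.76 log units; beyond the scatter), a step whose full size stays open because of the limit of > 222000 nM in this assay, at which 2 of the 3 values shown sit. The change from compound 3 to compound 4 is the same one, (3-aminopiperidin-1-yl in place of 4-sulfamoylpiperazin-1-yl on an aromatic carbon), with the same surroundings at the place. Compound 4 is therefore expected to show an at least 49-fold lower number from compound 3 to compound 4 (1.69 log units; beyond the scatter), an expectation resting on an at least 58-fold lower number from compound 2 to compound 1 (1.76 log units; beyond the scatter). Compound 4 is estimated at 4500 nM, with an expected range from 1200 nM to 25000 nM.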

Compound 4, half-maximal cytotoxic concentration: 4610 nM
For compound 4 the middle estimate is 1.0-fold (0.01 log units) below the measured one; the range from low to high includes it.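

In this assay, 3-aminopiperidin-1-yl in place of 4-sulfamoylpiperazin-1-yl on the second core gives an at least 48-fold lower number from compound 3 to compound 4 (1.68 log units; beyond the scatter). The change therefore carries from one core to the other in direction, with both steps beyond the scatter, but whether its size is the same on both cores cannot be read: the same change on two cores in this assay, an at least 58-fold lower number (1.76 log units; beyond the scatter) from compound 2 to compound 1 and an at least 48-fold lower number (1.68 log units; beyond the scatter) from compound 3 to compound 4; the limit leaves it open whether they differ The full size of each step stays open because compound 2 and compound 3 each stand only at a limit of the assay: the limit of > 222000 nM in this assay, at which 2 of the 4 values shown sit.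

Two pairs on two cores set no rule for any further core. The compounds shown also leave open how a carboxylic acid or a longer chain carrying an amine, on the same aromatic carbon, would read in this assay.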